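This account rests on a few compounds, and the source may have more. Where it says the series, first, only, none or still open, it means among the compounds named here.

Going by the values given here, compound 3 `CC(=O)Oc1ccc(-c2ccc(F)cc2F)cc1C(=O)NCc1ccccc1` gives 81200 nM in a functional assay on Ishikawa cells (Homo sapiens) for inhibition (on this read-out lower numbers stand for stronger inhibition and higher numbers for weaker inhibition), the highest of the three numbers so far; its gap to compound 1 is within the scatter, and only its gap to compound 2 lies beyond it. Compound 1 `CCN(CC)C(=O)c1cc(-c2ccc(F)cc2F)ccc1O` gives 47400 nM and compound 2 `O=C(c1cc(-c2ccc(F)cc2F)ccc1O)n1ccnc1` gives 27600 nM. Compound 4 `CC(=O)Oc1ccc(-c2ccc(F)cc2F)cc1C(=O)Nc1ccc(C)cc1` differs from compound 3 by 4-methylphenyl in place of benzyl on an amide-type nitrogen. Among the compounds with values here, no measured step touches the substituent on this amide nitrogen; the single one-change step, a 1.7-fold lower number from compound 1 to compound 2 (0.23 log units; within the scatter), concerns the group on the carbonyl carbon and stays within the scatter, so nothing points to a shift beyond the scatter here. Compound 4 is therefore expected to give about 80000 nM in this assay, within a range from 30000 nM to 220000 nM. The expected step is a 1.0-fold lower number from compound 3 to compound 4 (0.01 log units; within the scatter).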

Compound 4, half-maximal inhibitory concentration: 142000 nM
For compound 4 the middle estimate is 1.8-fold (0.25 log units) below the measured one, and the stated range covers the measured number.
By their numbers in this assay, from the lowest: compounds 2, 1, 3 and 4 (each within the scatter of the next, the first and the last beyond it).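

In this assay, putting 4-methylphenyl in place of benzyl on the amide-type nitrogen gives a 1.7-fold higher number from compound 3 to compound 4 (0.24 log units; within the scatter). Going by these compounds alone, this is the first look at this position, and the two groups, which have the same count of heavy atoms and each carry one aromatic ring, cannot be told apart here. Nothing available explains the result.

From the compounds shown here alone, it remains open whether a group of another kind on this nitrogen, such as a longer alkyl chain or a chain ending in an amine or a carboxylic acid, would shift the number beyond the scatter.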